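A few compounds are considered here, and "the series" means these few. Any claim that something is new, unique, unknown or untested is made for them only; others in the source may bear on it.

Two compounds share a core bearing a carbamate and an ethoxycarbonyl group. Compound 1 `CCOC(=O)c1cc(-c2cccc(OC(=O)NC3CCCCC3)c2)n(C)n1` carries a methyl on the aromatic nitrogen, and in an assay on isolated protein for inhibition of Fatty-acid amide hydrolase 1 (Homo sapiens), read by fluorescence, with a stated time of 30 min (on this read-out lower numbers stand for stronger inhibition and higher numbers for weaker inhibition), compound 1 gives 303 nM. Compound 2 `CCOC(=O)c1cc(-c2cccc(OC(=O)NC3CCCCC3)c2)n(-c2ccc(C)cc2)n1` carries a 4-methylphenyl there instead, and in this assay compound 2 gives 29 nM. Among the compounds with values here, that single change, a 10-fold lower number from compound 1 to compound 2 (1.02 log units; beyond the scatter), is the only step seen so far, and on it compound 2 stands with the lowest of the two numbers, with compound 1 as its only neighbour at a far higher number.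

Compound 3 `CCOC(=O)c1cc(-c2cccc(OC(=O)NC3CCCCC3)c2)n(-c2ccc(Cl)cc2Cl)n1` is not yet measured. It differs from compound 2 by 2,4-dichlorophenyl in place of 4-methylphenyl on an aromatic nitrogen. Within the data shown here, no measured step exchanges one aryl group for another on that nitrogen, so the step from compound 2 to compound 1 bears on it only indirectly: it shows that an aryl group on this nitrogen rather than a methyl goes with a much lower number, and compound 3 keeps an aryl group there. Compound 3 is therefore expected to stay close to compound 2, with a step of a 1.2-fold lower number from compound 2 to compound 3 (0.06 log units; within the scatter), which is within the scatter. The estimate for compound 3 in this assay is 25 nM, in a range from 8 nM to 80 nM.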

Compound 3, half-maximal inhibitory concentration: 123 nM
The estimate for compound 3 lay 4.9-fold (0.69 log units) below the measured number, and the stated range ends below it.
By their numbers in this assay, from the lowest: compound 2; then compound 3; then compound 1.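

In this assay, keeping an aryl group on the aromatic nitrogen does not by itself hold the number, since the exchange of 4-methylphenyl for 2,4-dichlorophenyl gives a 4.2-fold higher number from compound 2 to compound 3 (0.63 log units; beyond the scatter). The gain over methyl survives with this second aryl group, at a 2.5-fold lower number from compound 1 to compound 3 (0.39 log units; beyond the scatter), but it is smaller than the one seen with 4-methylphenyl, at a 10-fold lower number from compound 1 to compound 2 (1.02 log units; beyond the scatter), so the size of the gain depends on which aryl group sits at this position. Nothing available here accounts for the difference between the two aryl groups.

The step from 4-methylphenyl to 2,4-dichlorophenyl removes the methyl and brings in two chlorine atoms together, so the compounds shown cannot separate the contribution of each, and they leave open how an unsubstituted phenyl, a 4-chlorophenyl or a 4-methoxyphenyl would read on the same nitrogen. They also leave open whether the same ranking of methyl and the two aryl groups would hold if the ethoxycarbonyl group were replaced by a carboxylic acid or a primary amide.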